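A methoxy swap among compounds at the limit

A few compounds are considered here, and "the series" means these few. Any claim that something is new, unique, unknown or untested is made for them only; others in the source may bear on it.

In an ADME assay on MT4 cells (Homo sapiens) for cytotoxicity, read by MTT assay (a higher number here means that more compound is tolerated, a lower number that less compound is tolerated), compound 3 (`CCc1c(Cc2c(Cl)cccc2Cl)nc(SCC(=O)c2ccc(F)cc2)[nH]c1=O`) gives only a limit (> 55000 nM) and no number. Compound 2 (`CCc1c(Cc2c(Cl)cccc2Cl)nc(SCC(=O)c2ccccc2)[nH]c1=O`) also gives only a limit (> 52000 nM). Compound 1 (`COc1ccc(C(=O)CSc2nc(Cc3c(Cl)cccc3Cl)c(C)c(=O)[nH]2)cc1`) likewise gives only a limit (> 56000 nM). Compound 3 therefore stands among three limits, with no measured number to place it against.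

The next compound, compound 4 (`CCc1c(Cc2c(Cl)cccc2Cl)nc(SCC(=O)c2ccc(OC)cc2)[nH]c1=O`), has methoxy in place of fluoro on an aromatic carbon. Within the data shown here, the change sits para to a large group, on the same aromatic carbon that changes in the only measured step at this place (a step that the two limits leave unreadable from compound 2 to compound 3). That step gives no size to carry over, so no step beyond the scatter is expected in this assay, and no direction can be expected either. The expected change is small (an at least 1.0-fold lower number from compound 3 to compound 4 (0.00 log units; that floor lies within the scatter)). The estimate for compound 4 is 54000 nM, with an expected range from 25000 nM to 110000 nM, and a report of only a limit is the likeliest outcome.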

Compound 4, half-maximal cytotoxic concentration: > 54000 nM
Compound 4 was reported as a limit; the forecaster's own chance of this, stated with the estimate: 75%; the middle value lies on the limit itself.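

Compound 4, like compound 1, compound 2 and compound 3, is reported only as a limit, so the steps from those three compounds to compound 4 cannot be read. The compounds shown leave open what number any of them would give in this assay, and whether hydrogen, fluoro and methoxy at this place differ there at all.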